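Changing the benzyl group on the saturated carbon bound to nitrogen

A few compounds are considered here, and "the series" means these few. Any claim that something is new, unique, unknown or untested is made for them only; others in the source may bear on it.

Compound 1 `C[C@H](NC(=O)c1c(C(F)(F)F)nnn1Cc1ccc(F)cc1)c1ccc(C(=O)O)cc1` gives 2320 nM in a functional assay on CHO cells for antagonist activity at prostaglandin E2 receptor EP4 subtype (Homo sapiens), read by calcium flux, with a stated time of 15 min; a lower number here means a stronger inhibitor, a higher number a weaker inhibitor. Among the measured compounds shown here, compound 2 `C[C@H](NC(=O)c1c(-c2ccccc2)nnn1Cc1ccc(F)cc1)c1ccc(C(=O)O)cc1` gives 330 nM in this assay, the lowest of the two numbers so far. For the measured compounds named here, the only measured step, a 7.0-fold lower number from compound 1 to compound 2 (0.85 log units; beyond the scatter), concerns the substituent on the aromatic carbon, not the group on the saturated chain carbon bound to the aromatic nitrogen. Compound 3 `COc1ccc(Cn2nnc(-c3ccccc3)c2C(=O)N[C@@H](C)c2ccc(C(=O)O)cc2)cc1F` differs from compound 2 in exactly that place: 3-fluoro-4-methoxyphenyl in place of 4-fluorophenyl on a saturated chain carbon bound to an aromatic nitrogen. Going by the values given here, no measured step bears on this change, so nothing in hand points in either direction. The expected step is therefore a 1.1-fold lower number from compound 2 to compound 3 (0.04 log units; within the scatter), within the scatter. Compound 3 is estimated at 300 nM, with a range of 100 nM to 900 nM.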

Compound 3, half-maximal inhibitory concentration: 29.8 nM
Compound 3: middle estimate off by 10-fold (1.00 log units), on the high side, and the stated range ends above it.
By their numbers in this assay, from the lowest: compound 3; then compound 2; then compound 1.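

In this assay the group on the saturated chain carbon bound to an aromatic nitrogen proves to matter, with an 11-fold lower number from compound 2 to compound 3 (1.04 log units; beyond the scatter) on going from 4-fluorophenyl to 3-fluoro-4-methoxyphenyl. Numbers in this series can therefore fall through this place as well as through the aromatic carbon, and the entering group counts one hydrogen-bond acceptor where the leaving group counts none. No evidence in hand explains the step.

The compounds shown do not separate the contribution of the methoxy group from that of the fluorine. On these data alone, whether 4-methoxyphenyl, or an ethoxy group in place of the methoxy, would keep the low number remains open.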